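A few compounds are considered here, and "the series" means these few. Any claim that something is new, unique, unknown or untested is made for them only; others in the source may bear on it.

In a functional assay on KB cells (Homo sapiens) for cytotoxicity (a lower number here means that less compound is needed, a higher number that more compound is needed for the effect), compound 1 (`COC1=C(C)C(=O)/C(=C(O)/C=C/c2ccc(Br)cc2)C(=O)C1(C)C`) gives 1.9 ug/mL as its half-maximal concentration. Compound 2 (`COC1=C(C)C(=O)/C(=C(O)/C=C/c2ccc(C)cc2)C(=O)C1(C)C`) stands level with it at 1.9 ug/mL on the same read-out, and compound 3 (`COC1=C(C)C(=O)/C(=C(O)/C=C/c2c(C)cc(C)cc2C)C(=O)C1(C)C`) lies within the scatter of both at 1.84 ug/mL on that read-out. Compound 4 (`COC1=C(C)C(=O)/C(=C(O)/C=C/c2nccs2)C(=O)C1(C)C`) is still unmeasured. It carries 1,3-thiazol-2-yl in place of the 4-methylphenyl of compound 2 on a double-bonded chain carbon bound to a double-bonded chain carbon (1,3-thiazol-2-yl in place of 4-methylphenyl on a double-bonded chain carbon bound to a double-bonded chain carbon). Among the measured compounds shown here, one measured step bears on this, no change at the digits printed from compound 1 to compound 2 (within the scatter), and it concerns only a substituent on the aromatic ring. The values of compound 3 and compound 1 also lie within the scatter of each other. For the measured compounds named here, no measured compound exchanges the ring itself, so the evidence is indirect. The expected step, a 1.1-fold higher number from compound 2 to compound 4 (0.02 log units; within the scatter), is therefore none beyond the scatter, with no direction favoured. For compound 4 the estimated value is 2 ug/mL, with an expected range from 0.8 ug/mL to 5 ug/mL in this assay.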

Compound 4, concentration for half-maximal effect: 3 ug/mL
The estimate for compound 4 lay 1.5-fold (0.18 log units) below the measured number; the measured number falls inside the stated range.
By their numbers in this assay, from the lowest: compounds 3, 1, 2 and 4 (each within the scatter of the next).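

Among the compounds shown here, until this result, only a substituent on the aromatic ring had been exchanged; compound 4 exchanges the ring itself, on a double-bonded chain carbon bound to a double-bonded chain carbon, and this assay shows a 1.6-fold higher number from compound 2 to compound 4 (0.20 log units; within the scatter) for this change. The exchange of 4-bromophenyl for 1,3-thiazol-2-yl gives a 1.6-fold higher number from compound 1 to compound 4 (0.20 log units; within the scatter) at the same place, so a five-membered aromatic ring with 2 hetero atoms can stand there without a shift beyond the scatter. Nothing measured here bears on why the numbers fall as they do.

As far as these compounds go, it stays open whether a pyridine ring, an aromatic ring carrying an amine or a carboxylic acid, or a longer chain at this place would move the number beyond the scatter. The shared core also remains untested, as every compound shown keeps it unchanged.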